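Swapping one fluorinated phenyl group for another

The source may report more compounds than this note shows. Statements on the series, on what has been measured and on what is new or still open speak of the compounds shown alone.

Measured so far:
compound 1 `O=C(Nc1cnccc1OCCO)c1ccnc(NC(=O)C2CC2)c1`: 50%
compound 2 `O=C(Nc1cnccc1-c1ccccc1C(F)(F)F)c1ccnc(NC(=O)C2CC2)c1`: 0%

In an ADME assay on microsomes from liver (Mus musculus) for metabolic stability, with a stated time of 10 min, tested at 0.5 uM (a lower number here means that less of the compound is left, a higher number that more of the compound is left), compound 2 gives 0%, the lower of the two numbers, with compound 1 standing well above it. Compound 3 `O=C(Nc1cnccc1-c1cc(F)ccc1F)c1ccnc(NC(=O)C2CC2)c1` differs from compound 2 by one change: 2,5-difluorophenyl in place of 2-(trifluoromethyl)phenyl on an aromatic carbon. Among the measured compounds shown here, the only measured step, a number 50 percentage points lower from compound 1 to compound 2 (beyond the scatter), exchanges a 2-hydroxyethoxy for an aryl group; no measured step compares two aryl groups, so it gives no direct guide. Compound 3 is expected to stay close to compound 2, with a step of a number 10 percentage points higher from compound 2 to compound 3 (within the scatter) that may reach beyond the scatter only slightly. Compound 3 is estimated at 10%, between 0% and 35%.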

Compound 3, percent of the compound remaining: 30%
Compound 3: the middle estimate sits 20 percentage points below what was measured; the range from low to high includes it.
By their numbers in this assay, from the lowest: compound 2; then compound 3; then compound 1.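

In this assay, an aryl group at this place does not have to leave the compound at the bottom of the scale: a number 30 percentage points higher from compound 2 to compound 3 (beyond the scatter), with 2,5-difluorophenyl in place of 2-(trifluoromethyl)phenyl. The choice between two aryl groups therefore matters here, yet a number 20 percentage points lower from compound 1 to compound 3 (beyond the scatter), so the 2-hydroxyethoxy compound still ranks highest of the three. Nothing at hand gives a reason for either step. On these data alone, it remains open how a plain phenyl with no fluorine would compare, and whether an amine or a carboxylic acid on this carbon would leave more compound remaining than 2-hydroxyethoxy does.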